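The source may hold more compounds than are shown below. What is called first, only, known or untested is meant among the compounds shown, and "the series" means these compounds.

Measured so far:
compound 1, `CCCCCCCc1c(C)nc2cc(OC)ccc2c1O` — 3.69
compound 2, `CCCCCCCc1c(C)[nH]c2cc(OC)c(Cl)cc2c1=O` — < 3.83

In a physicochemical assay for lipophilicity, at pH 7.4 (on this read-out lower numbers stand for lower lipophilicity and higher numbers for higher lipophilicity), compound 1 gives 3.69. Compound 2 is reported in this assay only as a limit, < 3.83, and not as a number; (the limit of < 3.83 in this assay, at which 1 of the 2 values shown sits). Among the measured compounds shown here, no step between measured compounds is available, so where compound 2 truly stands is open. Compound 3, `C=C(CCCCC)c1c(C)[nH]c2cc(OC)c(Cl)cc2c1=O`, is not yet measured; it differs from compound 2 by a group of 7 heavy atoms (7 carbon; no ring) in place of a group of 7 heavy atoms (7 carbon; no ring), on an aromatic carbon. In this assay a step toward lower lipophilicity is expected, small and within the scatter. Compound 3 is expected at 3.4, with a range from 2.8 to 3.8. The expected step is a step that the limit leaves unreadable from compound 2 to compound 3.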

Compound 3, distribution coefficient: 3.58
Beside the measured number, compound 3's estimate is 0.18 log units below it, within the range that was stated.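

No step from compound 2 to compound 3 can be read in this assay, because compound 2 is reported only as a limit: the limit of < 3.83 in this assay, at which 1 of the 3 values shown sits.

From the compounds shown here alone, the size and direction of any change in this assay on replacing heptyl in compound 2 remain open.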